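From pyridin-4-yl to naphthalen-1-yl: an estimate for compound 3

A few compounds are considered here, and "the series" means these few. Any claim that something is new, unique, unknown or untested is made for them only; others in the source may bear on it.

compound 1, `Nc1scc(CN2CCN(c3ccccc3C(F)(F)F)CC2)c1C(=O)c1ccc(Cl)cc1`: -7.5%
compound 2, `Nc1scc(CN2CCN(c3ccncc3)CC2)c1C(=O)c1ccc(Cl)cc1`: 1.4%

Of the compounds shown here, two with a shared core have been measured in a functional assay on CHO cells with adenosine receptor A1 (Homo sapiens) as the target, read by cAMP accumulation and immunoassay, with a stated time of 6 min, tested at 0.1 uM; on this read-out lower numbers stand for a stronger effect and higher numbers for a weaker effect at the one concentration tested. In this assay compound 1 gives -7.5% and compound 2 gives 1.4%. Among the compounds with values here, the one measured step, a number 8.9 percentage points higher from compound 1 to compound 2 (within the scatter), lies within the scatter, so compound 2 stands level with compound 1 on these numbers; neither reading is far from zero.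

Compound 3, `Nc1scc(CN2CCN(c3cccc4ccccc34)CC2)c1C(=O)c1ccc(Cl)cc1`, differs from compound 2 by naphthalen-1-yl in place of pyridin-4-yl on an amine nitrogen in a ring. Within the data shown here, only the step of a number 8.9 percentage points higher from compound 1 to compound 2 (within the scatter) bears on this change, as it also exchanged the group on the ring nitrogen, and it moved the read-out by nothing beyond the scatter. Among the measured compounds shown here, no measured compound carries naphthalen-1-yl, so the data offer no further guide. The expected step is therefore a number 1.4 percentage points lower from compound 2 to compound 3 (within the scatter), nothing beyond the scatter. Compound 3 is estimated at 0%, with a range from -15% to 15%.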

Compound 3, a percentage reported as activity, at one concentration (the size of the read-out at that concentration, not a potency): 0%
Estimate against measurement, compound 3: no gap at the digits printed, within the range that was stated.
By their numbers in this assay, from the lowest: compounds 1, 3 and 2 (each within the scatter of the next).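

In this assay the change to naphthalen-1-yl gives a number 1.4 percentage points lower from compound 2 to compound 3 (within the scatter), and against 2-(trifluoromethyl)phenyl it gives a number 7.5 percentage points higher from compound 1 to compound 3 (within the scatter). The amine nitrogen in a ring therefore now carries a group of 2 six-membered aromatic rings of carbon only, with 10 heavy atoms against the 6 of pyridin-4-yl, and the read-out at this one concentration stays level with both earlier compounds. No further data are at hand to account for this result.

The compounds shown leave open whether a benzyl group or a short alkyl chain on this nitrogen would move the read-out beyond the scatter. They also leave open whether these three level readings would hold with a methoxy group in place of the chlorine.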